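The compounds below may be only part of what the source reports. "The series", "measured", "known", "first", "only" and "open" are said of these compounds alone.

Values in a functional assay on MCF7 cells (Homo sapiens) for antiproliferative activity; a higher number here means a weaker inhibitor, a lower number a stronger inhibitor:
- compound 1 `CC(C)=CCc1cc(C(=O)Nc2cc3ccc(OCC4CCN(C)C4)c(C)c3oc2=O)ccc1O`: 1550 nM
- compound 2 `CC(C)=CCc1cc(C(=O)Nc2cc3ccc(OCCCN4CCCCC4)c(C)c3oc2=O)ccc1O`: > 50000 nM
- compound 3 `CC(C)=CCc1cc(C(=O)Nc2cc3ccc(OCCCN4CCCC4)c(C)c3oc2=O)ccc1O`: 990 nM

The entry for compound 2, > 50000 nM, is a limit of the assay and not a number.

Compound 3, at 990 nM, stands level with compound 1, with a 1.6-fold lower number from compound 1 to compound 3 (0.19 log units; within the scatter). It lies far from compound 2, with an at least 50-fold lower number from compound 2 to compound 3 (1.70 log units; beyond the scatter).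

The next entry is compound 4 `CCCNCCCOc1ccc2cc(NC(=O)c3ccc(O)c(CC=C(C)C)c3)c(=O)oc2c1C`, not yet measured. The change is propylamino in place of pyrrolidin-1-yl on a saturated chain carbon, three bonds along the chain from an oxygen on an aromatic ring.

For the measured compounds named here, two measured steps bear on this place, and they disagree. The large step of an at least 32-fold higher number from compound 1 to compound 2 (1.50 log units; beyond the scatter) and its counterpart an at least 50-fold lower number from compound 2 to compound 3 (1.70 log units; beyond the scatter) show that a modest change here can matter a great deal, while a 1.6-fold lower number from compound 1 to compound 3 (0.19 log units; within the scatter) shows that another leaves the value unmoved. None of these steps replaces a ring with an open chain, so the size of the step in this assay remains uncertain.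

A small step toward a higher number, not clearly beyond the scatter, is expected, with a wide margin on the high side. The expected step is a 1.8-fold higher number from compound 3 to compound 4 (0.26 log units; within the scatter). For compound 4 the estimated value is 1800 nM, with an expected range of 400 nM to 15000 nM.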

Compound 4, half-maximal inhibitory concentration: 980 nM
Estimate against measurement, compound 4: 1.8-fold (0.26 log units) above, and the stated range covers the measured number.
By their numbers in this assay, from the lowest: compounds 4, 3 and 1 (each within the scatter of the next). At a limit, above all of these: compound 2.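

In this assay, propylamino, an open chain with a hydrogen-bond donor that pyrrolidin-1-yl lacks, replaces the ring with no shift in the value (a 1.0-fold lower number from compound 3 to compound 4 (0.00 log units; within the scatter)), so the ring is not required at this place for the value of compound 3 to hold. For the compounds shown here, compound 4 also stands level with compound 1 (a 1.6-fold lower number from compound 1 to compound 4 (0.20 log units; within the scatter)), which puts three different amine ends within the scatter of one another and leaves compound 2, with piperidin-1-yl, as the one compound against that pattern (an at least 51-fold lower number from compound 2 to compound 4 (1.70 log units; beyond the scatter)). That last step rests on a limit of the assay and not on a number: the limit of > 50000 nM in this assay, at which 1 of the 4 values shown sits.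

As far as these compounds go, whether the gap is particular to piperidin-1-yl or extends to other groups on the same chain carbon, such as a morpholine ring or a dimethylamino group, stays open. Also open, from the compounds shown here alone, is how far the open-chain end can vary, which a primary amine or a longer chain such as butylamino would test against the value of compound 4 (980 nM).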